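From Chloro to Bromo on an Aromatic Carbon

The source may report more compounds than this note shows. Statements on the series, on what has been measured and on what is new or still open speak of the compounds shown alone.

In an ADME assay on microsomes from liver (Mus musculus) for metabolic stability (on this read-out higher numbers stand for a longer-lived compound and lower numbers for a shorter-lived compound), compound 1 (`NS(=O)(=O)CC(=O)NCCSc1nonc1/C(=N/O)Nc1cccc(Cl)c1`) shows 1.26 h and stands level with compound 2 (`CS(=N)(=O)CC(=O)NCCSc1nonc1/C(=N/O)Nc1ccc(F)c(Br)c1`) at 1.25 h within the usual scatter of repeated measurements. Compound 3 (`NS(=O)(=O)CC(=O)NCCSc1nonc1/C(=N/O)Nc1cccc(Br)c1`), not yet measured, carries bromo in place of chloro on an aromatic carbon and is otherwise the same as compound 1. For the measured compounds named here, no measured pair shows this change, so no shift beyond the scatter is expected in this assay, in either direction. The expected step, a 1.1-fold lower number from compound 1 to compound 3 (0.02 log units; within the scatter), is a small one. For compound 3 the estimated half-life is 1.2 h (range 0.6 h to 2.3 h).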

Compound 3, half-life: 0.918 h
Beside the measured number, compound 3's estimate is 1.3-fold (0.12 log units) above it; the range from low to high includes it.
By their numbers in this assay, from the lowest: compounds 3, 2 and 1 (each within the scatter of the next).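

In this assay, bromo in place of chloro on an aromatic carbon, meta to a large group, gives a 1.4-fold lower number from compound 1 to compound 3 (0.14 log units; within the scatter). This is the only pair shown that differs in one place, and it gives no sign that exchanging these two halogens at this position matters for half-life. Nothing available explains this result. Still open, going by these compounds, is whether a different group at this position, such as methoxy or a carboxylic acid, would change the half-life beyond the scatter.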